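This account rests on a few compounds, and the source may have more. Where it says the series, first, only, none or still open, it means among the compounds named here.

Measured compounds in a functional assay on Bel-7402 cells (Homo sapiens) for inhibition, read by sulforhodamine B assay, with a stated time of 72 h, tested at 10 uM; on this read-out lower numbers stand for less inhibition and higher numbers for more inhibition at the one concentration tested (going by the name of the read-out):

compound 1, `C[C@H](Nc1ncnc2[nH]cnc12)c1nn(-c2cccc(F)c2)c2cc(F)ccc12`, gives -17%
compound 2, `C[C@H](Nc1ncnc2[nH]cnc12)c1nn(-c2cccnc2)c2cc(F)ccc12`, gives 8%
compound 3, `C[C@H](Nc1ncnc2[nH]cnc12)c1nn(-c2cc(F)cc(F)c2)c2cc(F)ccc12`, gives -8%

Compound 3 stands second highest of the three numbers in this assay. Its nearest neighbour is compound 1, whose value sits within the scatter of it, as a number 9 percentage points higher from compound 1 to compound 3 (within the scatter) shows; its furthest is compound 2, separated from it by a number 16 percentage points lower from compound 2 to compound 3 (beyond the scatter), a modest step beyond the scatter.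

The unmeasured compound 4, `C[C@H](Nc1ncnc2[nH]cnc12)c1nn(-c2ccncc2)c2cc(F)ccc12`, differs from compound 3 in one place: pyridin-4-yl in place of 3,5-difluorophenyl on an aromatic nitrogen. The entering group is a pyridinyl ring, as in compound 2, and the measured steps that bear on this exchange are those that swap a fluorinated phenyl for a pyridinyl on the same aromatic nitrogen: a number 25 percentage points higher from compound 1 to compound 2 (beyond the scatter) and, read in reverse, a number 16 percentage points lower from compound 2 to compound 3 (beyond the scatter). Both point the same way, toward higher inhibition with the pyridinyl group, in modest steps beyond the scatter. Within the data shown here, compound 4 carries pyridin-4-yl rather than the pyridin-3-yl of compound 2, so no measured compound matches it exactly, and the size of the step is uncertain.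

Compound 4 is therefore expected to rise by a number 16 percentage points higher from compound 3 to compound 4 (beyond the scatter) in this assay. The estimated value for compound 4 is 8%, with a range from -12% to 28%.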

Compound 4, a percentage reported as inhibition, at one concentration (the size of the read-out at that concentration, not a potency): 16%
For compound 4 the middle estimate is 8 percentage points below the measured one; low and high end bracket the measured number.
By their numbers in this assay, from the lowest: compounds 1 and 3 (each within the scatter of the next); then compounds 2 and 4 (each within the scatter of the next).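

In this assay, the rise seen earlier with pyridin-3-yl on the aromatic nitrogen also appears with a second pyridinyl ring: the pyridin-4-yl group gives a number 24 percentage points higher from compound 3 to compound 4 (beyond the scatter) against 3,5-difluorophenyl and a number 33 percentage points higher from compound 1 to compound 4 (beyond the scatter) against 3-fluorophenyl, the latter being the largest step in the set. Moving from pyridin-3-yl to pyridin-4-yl gives a number 8 percentage points higher from compound 2 to compound 4 (within the scatter), so this read-out does not separate the two pyridinyl rings, and at this position the contrast lies between those rings and the two fluorinated phenyl rings, not between the pyridinyl rings themselves. No measurement at hand explains why the pyridinyl rings and the fluorinated phenyl rings part in this way.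

The compounds shown leave open whether pyridin-2-yl, or a pyridinyl ring carrying an amine or a methoxy group, would stand with compound 4 at 16% or move away from it. They also leave open whether a saturated ring such as piperidin-4-yl on the same aromatic nitrogen would hold the gain, and how any of these compounds behave at other concentrations.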